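Isopropoxy to ethylamino on the carbonyl carbon

The source may report more compounds than this note shows. Statements on the series, on what has been measured and on what is new or still open speak of the compounds shown alone.

Measured in a functional assay on NTUB1 cells (Homo sapiens) for cytotoxicity, read by MTT assay, with a stated time of 72 h (on this read-out higher numbers stand for weaker inhibition and lower numbers for stronger inhibition), so far:
- compound 1 (`COc1ccc(OC)c(C(=O)/C=C/c2ccc(C(=O)OC(C)C)cc2)c1`) gives 4420 nM
- compound 2 (`COc1ccc(OC)c(C(=O)/C=C/c2ccc(C(=O)OCc3ccccc3)cc2)c1`) gives 13300 nM
- compound 3 (`CCNC(=O)c1ccc(/C=C/C(=O)c2cc(OC)ccc2OC)cc1`) awaits measurement

Compound 1 holds the lower of the two numbers. The change to compound 3 is ethylamino in place of isopropoxy on a carbonyl carbon. Within the data shown here, one measured step bears on it (a 3.0-fold higher number from compound 1 to compound 2 (0.48 log units; beyond the scatter)), a modest change of the group on the oxygen. Among the measured compounds shown here, no measured compound carries ethylcarbamoyl, so that step guides size only loosely. In this assay a step of similar size towards a higher number is expected (a 2.3-fold higher number from compound 1 to compound 3 (0.35 log units; beyond the scatter)). For compound 3 the estimated value is 10000 nM with an expected range from 3000 nM to 33000 nM in this read-out.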

Compound 3, half-maximal inhibitory concentration: 3760 nM
The estimate for compound 3 lay 2.7-fold (0.42 log units) above the measured number, and the stated range covers the measured number.
By their numbers in this assay, from the lowest: compounds 3 and 1 (each within the scatter of the next); then compound 2.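

In this assay the carbonyl carbon accepts ethylamino in place of isopropoxy with no change beyond the scatter (a 1.2-fold lower number from compound 1 to compound 3 (0.07 log units; within the scatter)), so this position is not limited to esters. Against benzyloxy, ethylamino gives a step beyond the scatter (a 3.5-fold lower number from compound 2 to compound 3 (0.55 log units; beyond the scatter)), leaving compound 2 apart from compound 1 and compound 3. No evidence is available to explain these results.

Open, going by these compounds, is whether benzylamino would match ethylamino or follow benzyloxy. On these data alone, a longer chain on the nitrogen, an unsubstituted amide and the free carboxylic acid also remain open.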